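The source may hold more compounds than are shown below. What is called first, only, known or untested is meant among the compounds shown, and "the series" means these compounds.

In an in vitro assay on U2OS cells for agonist activity at neurotensin receptor type 2 (Homo sapiens), read by reporter gene assay and beta-arrestin recruitment (a higher number here means that more compound is needed for the effect, a lower number that less compound is needed), the three measured compounds were read as follows, each one a limit of the assay rather than a number.

Compound 1 `COc1cc2nc(C3CCC3)nc(N3CCN(c4ccccc4C)CC3)c2cc1OC`: > 80000 nM.
Compound 2 `COc1cc2nc(C3CCC3)nc(N3CCN(c4ccccc4Cl)CC3)c2cc1OC`: > 80000 nM.
Compound 3 `CCc1nc(N2CCN(c3ccccc3OC)CC2)c2cc(OC)c(OC)cc2n1`: > 80000 nM.

Compound 3 therefore stands at the limit of > 80000 nM in this assay, at which 3 of the 3 values shown sit, and no number for it can be read. Among the measured compounds shown here, the only step between two measured compounds, a step that the two limits leave unreadable from compound 1 to compound 2, is likewise hidden by the two limits, and it concerns another position of the shared core, so it gives no measure of what a change at the carbon between two ring nitrogen atoms does.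

Compound 4 `COc1cc2nc(C3CCCC3)nc(N3CCN(c4ccccc4OC)CC3)c2cc1OC` differs from compound 3 by cyclopentyl in place of ethyl on an aromatic carbon. For the measured compounds named here, no measured step bears on this change in this assay. With compound 3 at the limit and nothing to indicate a gain, compound 4 is expected to stay at the limit as well, a step that the limit leaves unreadable from compound 3 to compound 4 at most in appearance. The estimate for compound 4 is 100000 nM, with a range from 20000 nM to 500000 nM.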

Compound 4, half-maximal effective concentration: > 80000 nM
Compound 4: a limit, no number; the forecaster's own chance of this, stated with the estimate: 85%; the middle value does not contradict the limit.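

No step from compound 3 to compound 4 can be read, as each compound gives only a limit in this assay: the limit of > 80000 nM in this assay, at which 4 of the 4 values shown sit.

The compounds shown leave open what cyclopentyl in place of ethyl does in this assay, and what any group on that aromatic carbon would do to give a readable number.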